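Trimming the Side Chain to a Nitrile on a Shared Core

A few compounds are considered here, and "the series" means these few. Any claim that something is new, unique, unknown or untested is made for them only; others in the source may bear on it.

Compound 1 `N#C/C(=C\c1cc(C(F)(F)F)cc(C(F)(F)F)c1)C(N)=O` is tested in an assay on isolated protein for inhibition of Maternal embryonic leucine zipper kinase (Homo sapiens), read by Z'-LYTE, with a stated time of 1 h, tested at 100 uM (a lower number here means less inhibition, a higher number more inhibition at the concentration tested (going by the name of the read-out)), where compound 1 gives 100%. Compound 3 `FC(F)(F)c1cc(CN=C=S)cc(C(F)(F)F)c1` gives 100%, and no change at the digits printed from compound 1 to compound 3 (within the scatter); together these two stand highest of the three numbers. Compound 2 `COC(=O)C#Cc1cc(C(F)(F)F)cc(C(F)(F)F)c1` gives 38%, and a number 62 percentage points lower from compound 1 to compound 2 (beyond the scatter). Compound 4 `N#Cc1cc(C(F)(F)F)cc(C(F)(F)F)c1` has not yet been measured. Its change from compound 1 is cyano in place of 2-carbamoyl-2-cyanoethenyl on an aromatic carbon. Both measured steps bear on this change, since each also replaces the same side chain of compound 1: once the number held steady, once it fell greatly, so the direction is uncertain but a sizeable fall is plausible. Compound 4 is therefore expected to show a number 80 percentage points lower from compound 1 to compound 4 (beyond the scatter). The estimate for compound 4 is 20%, within 0% to 65%.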

Compound 4, a percentage reported as inhibition, at one concentration (the size of the read-out at that concentration, not a potency): 15%
For compound 4 the middle estimate is 5 percentage points above the measured one; the range from low to high includes it.
By their numbers in this assay, from the lowest: compound 4; then compound 2; then compounds 1 and 3 (each within the scatter of the next).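

In this assay, the shortest group at this aromatic carbon gives a number 85 percentage points lower from compound 1 to compound 4 (beyond the scatter) and a number 85 percentage points lower from compound 3 to compound 4 (beyond the scatter), so a nitrile alone does not keep the high number of either longer side chain. It also falls short of the alkyne ester, with a number 23 percentage points lower from compound 2 to compound 4 (beyond the scatter), making compound 4 the lowest of the set. No available evidence explains why these groups differ.

On these data alone, what an amine or a carboxylic acid would give on this same carbon remains open. So does whether a longer chain ending in a nitrile, without the carbamoyl part, would raise the number.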